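Ethoxycarbonyl to Dimethylaminoethyl: What to Expect for Compound 4

A few compounds are considered here, and "the series" means these few. Any claim that something is new, unique, unknown or untested is made for them only; others in the source may bear on it.

Of the compounds shown here, three built on one shared core have been measured in a functional assay (B cells) with Mus musculus as the target; a lower number here means that less compound is needed, a higher number that more compound is needed for the effect. Compound 1 `Nc1nc(O)c2c(n1)n(C1OC(CO)[C@@H](O)[C@H]1O)c(=O)n2Cc1ccc(Cl)cc1` gives 14 uM. Compound 2 `NC(=O)Cn1c(=O)n(C2OC(CO)[C@@H](O)[C@H]2O)c2nc(N)nc(O)c21` gives 190 uM, and compound 3 `CCOC(=O)Cn1c(=O)n(C2OC(CO)[C@@H](O)[C@H]2O)c2nc(N)nc(O)c21` gives 48 uM. Compound 3 thus holds the second highest of the three numbers: it sits nearer to compound 1, with a 3.4-fold higher number from compound 1 to compound 3 (0.54 log units; beyond the scatter), than to compound 2, with a 4.0-fold lower number from compound 2 to compound 3 (0.60 log units; beyond the scatter).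

Compound 4 `CN(C)CCCn1c(=O)n(C2OC(CO)[C@@H](O)[C@H]2O)c2nc(N)nc(O)c21` has not yet been measured. It differs from compound 3 in a single place: 2-(dimethylamino)ethyl in place of ethoxycarbonyl on a saturated chain carbon bound to an aromatic nitrogen.

Which measured steps bear on this? Both changes made at the saturated chain carbon bound to an aromatic nitrogen moved the number beyond the scatter, namely a 14-fold higher number from compound 1 to compound 2 (1.13 log units; beyond the scatter) and a 3.4-fold higher number from compound 1 to compound 3 (0.54 log units; beyond the scatter). The change from amino to ethoxy on the carbonyl carbon also counted, as seen in a 4.0-fold lower number from compound 2 to compound 3 (0.60 log units; beyond the scatter). Going by the values given here, none of these, however, introduces a 2-(dimethylamino)ethyl group, so no direct precedent fixes the direction for compound 4; the firm lesson is only that this position matters. Compound 4 is therefore expected to stay close to its neighbour, the expected step being a 1.2-fold lower number from compound 3 to compound 4 (0.08 log units; within the scatter), with either direction possible. For compound 4 the estimated value in this assay is 40 uM, within a range from 10 uM to 160 uM.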

Compound 4, concentration for half-maximal effect: 194 uM
Beside the measured number, compound 4's estimate is 4.9-fold (0.69 log units) below it; the whole stated range lies below it.
By their numbers in this assay, from the lowest: compound 1; then compound 3; then compounds 2 and 4 (each within the scatter of the next).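

In this assay, the change to 2-(dimethylamino)ethyl on a saturated chain carbon bound to an aromatic nitrogen produced a clear rise in the number (a 4.0-fold higher number from compound 3 to compound 4 (0.61 log units; beyond the scatter)), even though the swap leaves the heavy-atom count unchanged. The carbamoyl and 2-(dimethylamino)ethyl groups cannot be told apart at this place (a 1.0-fold higher number from compound 2 to compound 4 (0.01 log units; within the scatter)), and the step from 4-chlorophenyl to 2-(dimethylamino)ethyl is large (a 14-fold higher number from compound 1 to compound 4 (1.14 log units; beyond the scatter)), so a group with no carbonyl falls level with one that has a carbonyl, while ethoxycarbonyl, which also has a carbonyl, stands apart from both; among these four compounds the presence of a carbonyl does not sort the numbers. Nothing available explains why these groups fall where they do.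

The compounds shown leave open whether it is the dimethylamino end of the chain or the chain itself that sets the number of compound 4, since a primary amine or a plain propyl chain at the same place does not appear among them. They also leave open how a carboxylic acid in place of the ethoxycarbonyl group of compound 3 would read.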